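Methylsulfanyl for aminoamino on the pyrimidinone-type core

The source may report more compounds than this note shows. Statements on the series, on what has been measured and on what is new or still open speak of the compounds shown alone.

Measured compounds:
compound 1 `CN(C)c1ccc(-c2nc(NN)n(C)c(=O)c2C#N)cc1` — 63 ug/mL
compound 2 `Cn1c(NN)nc(-c2cccc(O)c2O)c(C#N)c1=O` — 31 ug/mL
compound 3 `CSc1nc(-c2cccc(O)c2O)c(C#N)c(=O)n1C` — 41 ug/mL

All three were run in a functional assay on microsomes for inhibition, with a stated time of 1 h; a higher number here means a weaker inhibitor, a lower number a stronger inhibitor. Compound 1 and compound 2 carry the same aminoamino group on the shared core and differ in the aryl group; the difference between these two cores is not broken down here. What the values show is that compound 1 gives the higher number of the two, while compound 1 against compound 3 is within the usual scatter.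

Compound 4 `CSc1nc(-c2ccc(N(C)C)cc2)c(C#N)c(=O)n1C` has not yet been measured. It is made from compound 1 by methylsulfanyl in place of aminoamino on an aromatic carbon. The same kind of change links two measured compounds: compound 3 is made from compound 2 by methylsulfanyl in place of aminoamino on an aromatic carbon. The place descriptions differ only in the size of one group meta to the changed carbon, a group of 9 heavy atoms in compound 1 and a group of 8 heavy atoms in compound 2, so the change is of the same kind, not the same. That step gave a 1.3-fold higher number from compound 2 to compound 3 (0.12 log units; within the scatter), a small shift that does not clear the scatter.

Resting on the step from compound 2 to compound 3, which was within the scatter, compound 4 is expected to move by about a 1.2-fold higher number from compound 1 to compound 4 (0.09 log units; within the scatter) in this assay. Compound 4 is therefore estimated at 78 ug/mL, with a range of 40 ug/mL to 150 ug/mL.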

Compound 4, half-maximal inhibitory concentration: 98 ug/mL
Compound 4: middle estimate off by 1.3-fold (0.10 log units), on the low side; the range from low to high includes it.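

In this assay, methylsulfanyl in place of aminoamino on the core of compound 1 gives a 1.6-fold higher number from compound 1 to compound 4 (0.19 log units; within the scatter), and the step agrees with the one seen earlier on the core of compound 2: the same change on two cores in this assay, a 1.3-fold higher number (0.12 log units; within the scatter) from compound 2 to compound 3 and a 1.6-fold higher number (0.19 log units; within the scatter) from compound 1 to compound 4, 1.2-fold (0.07 log units) apart, within the scatter of two such steps

Within these two compounds pairs, the exchange therefore carries over from one core to the other as a step that stays inside the scatter, and the difference in the aryl group does not separate the two steps. This does not establish a real effect of the exchange in either direction, since neither step clears the scatter and their shared direction cannot be read as a trend, and two pairs say nothing about how the change behaves on cores bearing any other aryl group.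

The compounds shown leave open whether other groups on the same aromatic carbon, such as a morpholine, a plain amine or a longer chain like ethylsulfanyl, would give a step that clears the scatter. They also leave open whether the exchange stays this small on an aryl group carrying a carboxylic acid or a halogen such as chlorine.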